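The compounds below may be only part of what the source reports. "The series", "measured", "known", "first", "only" and "open" are said of these compounds alone.

Compound 1, `Cc1nc(N[C@@H]2C[C@H]3CC[C@@H]2C3)c2cc(-c3ccc(C(F)(F)F)cc3)ccc2n1`, in a functional assay for positive allosteric modulation of GABA-B receptor (Homo sapiens), read by GTPgammaS binding; a lower number here means that less compound is needed, a higher number that more compound is needed for the effect: 771 nM. Compound 2, `FC(F)(F)c1ccc(-c2ccc3nc(Cl)nc(N[C@@H]4C[C@H]5CC[C@@H]4C5)c3c2)cc1`, in this assay: 637 nM.

Compound 2 has the lower of the two numbers, but the step of a 1.2-fold lower number from compound 1 to compound 2 (0.08 log units; within the scatter) stays within the scatter, so the two compounds cannot be told apart on these data. Compound 3, `Fc1ccc(-c2ccc3nc(Cl)nc(N[C@@H]4C[C@H]5CC[C@@H]4C5)c3c2)cc1`, is the next variation on the shared core of compound 2; the change is fluoro in place of trifluoromethyl on an aromatic carbon. For the measured compounds named here, the only measured step, from compound 1 to compound 2, concerns the substituent on a different aromatic carbon and says nothing about the group that is exchanged here, so no measured step bears directly on this change. Without a comparable precedent, the expectation for compound 3 rests on the values of compound 1 and compound 2 alone, and the step of a 1.6-fold higher number from compound 2 to compound 3 (0.20 log units; within the scatter) is estimated to be modest and uncertain in direction. Compound 3 is therefore expected to give about 1000 nM, with a range from 350 nM to 3000 nM.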

Compound 3, half-maximal effective concentration: 294 nM
Compound 3: middle estimate off by 3.4-fold (0.53 log units), on the high side; the measured number lies below the stated range.
By their numbers in this assay, from the lowest: compound 3; then compounds 2 and 1 (each within the scatter of the next).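

Trifluoromethyl, para to a large group, can be exchanged for fluoro with the number moving down: the change gives a 2.2-fold lower number from compound 2 to compound 3 (0.34 log units; beyond the scatter). This is the first step among these compounds that lies beyond the scatter, whereas the change at the other aromatic carbon gave a 1.2-fold lower number from compound 1 to compound 2 (0.08 log units; within the scatter) and left compound 1 and compound 2 indistinguishable. The result therefore marks this position as one where the substituent can change the number in this assay, and it shows that the four heavy atoms of trifluoromethyl are not needed to keep the effect. Nothing available accounts for the size or direction of this step.

On these data alone, whether the trend continues with a hydrogen, a chlorine, a methoxy group or a nitrile at this position remains open. Also open, as far as these compounds go, is whether fluoro gives a similar step when methyl replaces chloro on the shared core.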